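The source may hold more compounds than are shown below. What is called first, only, known or untested is meant among the compounds shown, and "the series" means these compounds.

Compound 2 `Oc1ccccc1/C=N/c1cc2ccccc2nc1-c1ccccc1F` and compound 1 `COc1ccc(/C=N/c2cc3ccccc3nc2-c2ccccc2F)c(O)c1` share one core and differ at a single aromatic carbon. In a functional assay on HepG2 cells (Homo sapiens) for cytotoxicity, read by MTT assay, with a stated time of 48 h (a lower number here means a stronger inhibitor, a higher number a weaker inhibitor), compound 1 gives 31100 nM, and compound 2 gives 20200 nM; the step of a 1.5-fold lower number from compound 1 to compound 2 (0.19 log units; within the scatter) leaves the two numbers within the scatter of each other, so neither stands apart. Compound 3 `Oc1cccc(/C=N/c2cc3ccccc3nc2-c2ccccc2F)c1O` carries hydroxy in place of hydrogen on an aromatic carbon. Within the data shown here, the only measured step concerns a different group on the same ring and was itself within the scatter, so for compound 3 in this assay no movement beyond the scatter is expected, with an estimate of 20000 nM, range 8000 nM to 50000 nM, amounting to an expected step of a 1.0-fold lower number from compound 2 to compound 3 (0.00 log units; within the scatter).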

Compound 3, half-maximal inhibitory concentration: > 40000 nM
Compound 3 gave a limit, no number (the forecaster's own chance of this, stated with the estimate: 10%); middle value at least 2.0-fold (0.30 log units) away from the limit.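

In this assay compound 3 gives > 40000 nM, which is a limit of the assay and not a number: the limit of > 40000 nM in this assay, at which 1 of the 3 values shown sits. Hydroxy ortho to the existing hydroxy group gives an at least 1.9-fold higher number from compound 2 to compound 3 (0.29 log units; that floor lies within the scatter), and the wider exchange gives an at least 1.2-fold higher number from compound 1 to compound 3 (0.10 log units; that floor lies within the scatter). Going by these compounds, both floors lie within the scatter, so this position shows no lower number with 2,3-dihydroxyphenyl, while the true size of either step remains unknown.

On these data alone, whether the step extends beyond the scatter remains open. So does the outcome at this position with an amine or a carboxylic acid in place of hydroxy.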